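This account rests on a few compounds, and the source may have more. Where it says the series, first, only, none or still open, it means among the compounds named here.

Series notes. Compound 1 `Fc1ccc(NC(=S)Nc2nc3ccc(F)cc3s2)cc1` carries a fluoro on the fused ring of the shared core; in a functional assay on B16-F10 cells (Mus musculus) for cytotoxicity, read by MTT assay, with a stated time of 48 h (a lower number here means a stronger inhibitor, a higher number a weaker inhibitor), compound 1 gives 47700 nM. That is the only numerical result so far. Compound 2 `Fc1ccc2nc(NC(=S)Nc3ccccc3)sc2c1` differs by hydrogen in place of fluoro on an aromatic carbon of the other ring. For compound 2 in this assay the result is > 50000 nM, which is a limit of the assay and not a number. The step of an at least 1.0-fold higher number from compound 1 to compound 2 (0.02 log units; that floor lies within the scatter) therefore has only a floor. Among the measured compounds shown here, the one measured step touches (the limit of > 50000 nM in this assay, at which 1 of the 2 values shown sits).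

Compound 3 `CCOc1ccc2nc(NC(=S)Nc3ccc(F)cc3)sc2c1` arises from compound 1 by ethoxy in place of fluoro on an aromatic carbon. For the measured compounds named here, no measured step alters this position of the core, so the step from compound 1 to compound 2 bears on it only in showing that the series sits near the upper reach of this assay. The expectation is a step within the scatter, a 1.2-fold lower number from compound 1 to compound 3 (0.08 log units; within the scatter), with little guidance on direction. Compound 3 is therefore estimated at 40000 nM in this assay, in a range from 15000 nM to 100000 nM, with a real chance that only a limit is reported.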

Compound 3, half-maximal inhibitory concentration: > 50000 nM
Compound 3: a limit, no number (the forecaster's own chance of this, stated with the estimate: 35%); middle value at least 1.2-fold (0.09 log units) away from the limit.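

In this assay, ethoxy in place of fluoro on an aromatic carbon brings 3 heavy atoms and 1 hydrogen-bond acceptor where fluoro had 1 heavy atom and none, yet the result gives only a floor: an at least 1.0-fold higher number from compound 1 to compound 3 (0.02 log units; that floor lies within the scatter). Compound 3 gives > 50000 nM, which is a limit of the assay and not a number, so the step shows neither a real loss nor a real gain at this position. What is new is that a change at this position, and not only the change on the other ring, ends at a limit instead of a number: the limit of > 50000 nM in this assay, at which 2 of the 3 values shown sit.

Open is whether any group at this position gives a clearly lower number than compound 1 in this assay: an amine, a hydroxyl or a carboxylic acid here, or a longer chain than ethoxy, has no value among the compounds shown. Also open, on these data alone, is how far the true value of compound 3 lies from that of compound 1, and whether a chloro or a methoxy on the other ring would move the number at all.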